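The compounds below may be only part of what the source reports. "The series", "measured", "known", "first", "only" and "open" are said of these compounds alone.

Measured so far:
- compound 1 `N#CC1=C(N)Oc2c(N)cc3nc4ccccc4nc3c2C12C(=O)N(Cc1cnnn1-c1ccc(Cl)cc1)c1ccccc12`: in a functional assay on HCT-116 cells (Homo sapiens) for antiproliferative activity, read by MTT assay, with a stated time of 48 h (on this read-out lower numbers stand for stronger inhibition and higher numbers for weaker inhibition), compound 1 gives > 50000 nM, which is a limit of the assay and not a number.
- compound 2 `N#CC1=C(N)Oc2c(N)cc3nc4ccccc4nc3c2C12C(=O)N(Cc1cnnn1-c1ccccc1Br)c1ccccc12`: in this assay compound 2 gives 12400 nM.
- compound 3 `CC(=O)Nc1ccc(-n2nncc2CN2C(=O)C3(C(C#N)=C(N)Oc4c(N)cc5nc6ccccc6nc5c43)c3ccccc32)cc1`: in this assay compound 3 gives > 50000 nM, again a limit and not a number.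

Compound 3 therefore stands at the limit of > 50000 nM in this assay, at which 2 of the 3 values shown sit, with no number to rank it. Compound 4 `CCOc1ccc(-n2nncc2CN2C(=O)C3(C(C#N)=C(N)Oc4c(N)cc5nc6ccccc6nc5c43)c3ccccc32)cc1` differs from it by ethoxy in place of acetamido on an aromatic carbon. The measured steps all change the phenyl on the triazole nitrogen: an at least 4.0-fold lower number from compound 1 to compound 2 (0.60 log units; beyond the scatter), an at least 4.0-fold higher number from compound 2 to compound 3 (0.60 log units; beyond the scatter), and a step that the two limits leave unreadable from compound 1 to compound 3. None exchanges one group for another at the place para to a large group, so they bear on the change only loosely. Compound 4 is expected near the limit, at 50000 nM, between 15000 nM and 150000 nM. The expected step is a number no higher from compound 3 to compound 4 (the limit leaves the size open), none beyond the scatter.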

Compound 4, half-maximal inhibitory concentration: > 50000 nM
Compound 4 was reported as a limit; the forecaster's own chance of this, stated with the estimate: 60%; the middle value sits exactly at the limit.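

Ethoxy para to a large group gives no readable number any more than acetamido does: in this assay compound 4 gives > 50000 nM, which is a limit of the assay and not a number. The steps from compound 1 and compound 3 to compound 4 cannot be read, as both ends are limits. The one readable step is an at least 4.0-fold higher number from compound 2 to compound 4 (0.60 log units; beyond the scatter), which leaves compound 2 as the only compound with a number: the limit of > 50000 nM in this assay, at which 3 of the 4 values shown sit.

Still open, going by these compounds, is whether an amine or a carboxylic acid para to a large group would give a readable number. On these data alone, what the two groups at this place would do on a core with a readable number also stays open.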